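From compound 3 to compound 4: a side-chain exchange

The compounds below may be only part of what the source reports. "The series", "measured", "known", "first", "only" and "open" are said of these compounds alone.

In an ADME assay on HEF cells (Homo sapiens) for cytotoxicity, read by MTT assay, with a stated time of 72 h (on this read-out lower numbers stand for stronger inhibition and higher numbers for weaker inhibition), compound 1 (`C=C1C2=C(C(=O)N1OC)[C@H](OC(=O)CSc1nc3ccccc3o1)[C@@](C)(O)[C@H](CCCCC)O2`) gives 9300 nM and compound 2 (`C=C1C2=C(C(=O)N1OC)[C@H](OC(=O)CSc1nc3ccccc3s1)[C@@](C)(O)[C@H](CCCCC)O2`) gives 11000 nM while compound 3 (`C=C1C2=C(C(=O)N1OC)[C@H](OC(=O)CCCCCl)[C@@](C)(O)[C@H](CCCCC)O2`) gives 11000 nM on the same read-out. Compound 3 is level with compound 2 at the digits shown, and all three numbers lie within the scatter of one another.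

Compound 4 (`C=C1C2=C(C(=O)N1OC)[C@H](OC(=O)CSc1nc3ccccc3[nH]1)[C@@](C)(O)[C@H](CCCCC)O2`) carries (1H-benzimidazol-2-yl)sulfanyl in place of 3-chloropropyl on a saturated chain carbon bound to a carbonyl carbon. The difference counts as (1H-benzimidazol-2-yl)sulfanyl in place of 3-chloropropyl on a saturated chain carbon bound to a carbonyl carbon and the shared core stays untouched.

Among the measured compounds shown here, three measured steps bear on this change. The closest are the exchanges of a fused sulfanyl group for 3-chloropropyl, seen as a 1.2-fold higher number from compound 1 to compound 3 (0.07 log units; within the scatter) and as no change at the digits printed from compound 2 to compound 3 (within the scatter) with both inside the scatter. Swapping 1,3-benzoxazol-2-yl for 1,3-benzothiazol-2-yl on the sulfur gave a 1.2-fold higher number from compound 1 to compound 2 (0.07 log units; within the scatter) and also stayed inside the scatter. For the measured compounds named here, no measured compound carries the (1H-benzimidazol-2-yl)sulfanyl group itself, so the estimate rests on its two nearest relatives.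

No shift beyond the scatter is expected in this assay and the estimated step is a 1.1-fold lower number from compound 3 to compound 4 (0.04 log units; within the scatter) with no firm direction. For compound 4 the expected value is 10000 nM within an estimated range of 5000 nM to 20000 nM on this read-out.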

Compound 4, half-maximal inhibitory concentration: 11000 nM
For compound 4 the middle estimate is 1.1-fold (0.04 log units) below the measured one; low and high end bracket the measured number.
By their numbers in this assay, from the lowest: compounds 1, 2, 3 and 4 (each within the scatter of the next).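

In this assay the third fused sulfanyl group behaves like the first two: the exchange for 3-chloropropyl on a saturated chain carbon bound to a carbonyl carbon gives no change at the digits printed from compound 3 to compound 4 (within the scatter) and the exchanges on the sulfur give no change at the digits printed from compound 2 to compound 4 (within the scatter) and a 1.2-fold higher number from compound 1 to compound 4 (0.07 log units; within the scatter). The earlier compounds had not shown this for an entering group counted with 1 hydrogen-bond donor and 2 hydrogen-bond acceptors, so the flat picture at this position now extends to 1H-benzimidazol-2-yl on the sulfur, and none of the four compounds goes against it. No measurement shown offers an explanation for this flat picture.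

Whether this position stays as flat with a carboxylic acid, a primary amine or a longer chain in place of 3-chloropropyl remains open, since all groups shown here are either a chlorine-ended chain or a fused aromatic sulfanyl group. Also open, going by these compounds, is whether any change to the shared core itself would shift the number in this assay, as the four compounds differ only in this side chain.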